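The compounds below may be only part of what the source reports. "The series", "measured", "known", "first", "only" and "open" are said of these compounds alone.

Working notes on the series. In a functional assay on U-937 cells (Homo sapiens) for cytotoxicity, read by MTT assay, with a stated time of 3 days (on this read-out higher numbers stand for weaker inhibition and lower numbers for stronger inhibition), compound 2 (`N#Cc1c(Nc2nccs2)nc(SCc2nc3ccccc3[nH]2)nc1-c1ccccc1`) gives 3.8 nM and compound 1 (`CCNc1nc(SCc2nc3ccccc3[nH]2)nc(-c2ccccc2)c1C#N`) gives 2.63 nM. For the measured compounds named here, these two numbers lie within the scatter of each other, so compound 2 stands level with the only other measured compound. The unmeasured compound 3 (`N#Cc1c(NC(N)=S)nc(SCc2nc3ccccc3[nH]2)nc1-c1ccccc1`) differs from compound 2 as follows: a group of 3 heavy atoms (1 carbon, 1 nitrogen, 1 sulfur; no ring) in place of a group of 5 heavy atoms (3 carbon, 1 nitrogen, 1 sulfur; one five-membered aromatic ring with 2 hetero atoms), on a nitrogen on an aromatic ring. Going by the values given here, one measured step bears on this change, at the same place on a nitrogen on an aromatic ring: a 1.4-fold higher number from compound 1 to compound 2 (0.16 log units; within the scatter). Among the compounds with values here, that single step stayed within the scatter, and no measured compound carries the entering group, so support is thin. No step beyond the scatter is therefore expected in this assay, in either direction. The expected step is a 1.2-fold higher number from compound 2 to compound 3 (0.07 log units; within the scatter). The estimate for compound 3 is 4.5 nM, with an expected range of 1.2 nM to 18 nM.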

Compound 3, half-maximal inhibitory concentration: 20 nM
For compound 3 the middle estimate is 4.4-fold (0.65 log units) below the measured one, outside the stated range (above it).
By their numbers in this assay, from the lowest: compounds 1 and 2 (each within the scatter of the next); then compound 3.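

This position on the nitrogen on an aromatic ring is not indifferent to its substituent in this assay: ethyl and 1,3-thiazol-2-yl had stayed within the scatter of each other, but the open-chain group of 3 heavy atoms gives a 5.3-fold higher number from compound 2 to compound 3 (0.72 log units; beyond the scatter) and a 7.6-fold higher number from compound 1 to compound 3 (0.88 log units; beyond the scatter). Both steps are beyond the scatter, so the entering group separates from two otherwise quite different groups, one with a ring and one without. No evidence on why the number rises accompanies these compounds.

The compounds shown leave open whether the sulfur of the entering group matters, since a urea carrying oxygen in its place does not appear among them. They also leave open how a plain amino group or an acetyl group on the same nitrogen would compare.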